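The compounds below may be only part of what the source reports. "The series", "measured", "known", "first", "only" and "open" are said of these compounds alone.

In a functional assay on SN12C cells (Homo sapiens) for inhibition, read by sulforhodamine B assay, with a stated time of 48 h (a higher number here means a weaker inhibitor of growth, a lower number a stronger inhibitor of growth), compound 3 `O=C(Cc1csc2nc(-c3ccc(Br)cc3)cn12)N/N=C/c1ccc(O)cc1` gives 15500 nM, and compound 1 `O=C(Cc1csc2nc(-c3ccc(Br)cc3)cn12)N/N=C/c1ccccc1` gives 13200 nM. These two agree within the scatter. Only compound 2 `O=C(Cc1csc2nc(-c3ccc(Br)cc3)cn12)N/N=C/c1ccccc1O` stands apart, at 3310 nM. Compound 4 `COc1cccc(OC)c1/C=N/NC(=O)Cc1csc2nc(-c3ccc(Br)cc3)cn12` carries 2,6-dimethoxyphenyl in place of 4-hydroxyphenyl on a carbon with a double bond to nitrogen. The nearest evidence comes from the hydroxyphenyl series. There, a 4.0-fold lower number from compound 1 to compound 2 (0.60 log units; beyond the scatter) and a 4.7-fold higher number from compound 2 to compound 3 (0.67 log units; beyond the scatter) were modest, whereas a 1.2-fold higher number from compound 1 to compound 3 (0.07 log units; within the scatter) stayed within the scatter. For the measured compounds named here, no measured compound carries 2,6-dimethoxyphenyl, so these steps only suggest a scale. The step expected in this assay is a 1.6-fold lower number from compound 3 to compound 4 (0.19 log units; within the scatter), a small move toward a lower number and no shift beyond the scatter. For compound 4 the estimated value is 10000 nM, with an expected range of 3500 nM to 30000 nM.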

Compound 4, concentration for 50% growth inhibition: 20900 nM
The estimate for compound 4 lay 2.1-fold (0.32 log units) below the measured number; measured number inside the range.
By their numbers in this assay, from the lowest: compound 2; then compounds 1, 3 and 4 (each within the scatter of the next).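

In this assay, 2,6-dimethoxyphenyl on the carbon with a double bond to nitrogen cannot be told apart from 4-hydroxyphenyl (a 1.3-fold higher number from compound 3 to compound 4 (0.13 log units; within the scatter)) or from phenyl (a 1.6-fold higher number from compound 1 to compound 4 (0.20 log units; within the scatter)). Only 2-hydroxyphenyl stands apart among the four groups shown (a 6.3-fold higher number from compound 2 to compound 4 (0.80 log units; beyond the scatter)), and the two methoxy groups of compound 4 do not reproduce the lower number of compound 2. No evidence is available to explain this difference. The compounds shown leave open how a phenyl ring bearing an amine or a carboxylic acid would read at this place. They also leave open whether the lower number of compound 2 requires the hydroxy group itself.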